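A few compounds are considered here, and "the series" means these few. Any claim that something is new, unique, unknown or untested is made for them only; others in the source may bear on it.

- Compound 1 `Cc1ccc2nc(NCCCCOc3cc(O)c4c(=O)cc(-c5ccccc5)oc4c3)sc2c1` gives 28.1 ug/mL
- Compound 2 `O=c1cc(-c2ccccc2)oc2cc(OCCCCNc3nc4ccc(Br)cc4s3)cc(O)c12` gives 16.1 ug/mL

In a physicochemical assay, read by spectrophotometry, with a stated time of 25 min (on this read-out higher numbers stand for weaker inhibition and lower numbers for stronger inhibition), compound 2 stands at 16.1 ug/mL and so lies within the scatter of compound 1 (28.1 ug/mL). Compound 3 `O=c1cc(-c2ccccc2)oc2cc(OCCCCNNc3nc4ccccc4s3)cc(O)c12` carries (1,3-benzothiazol-2-yl)amino in place of 6-bromo-1,3-benzothiazol-2-yl on an amine nitrogen. Within the data shown here, the only measured step (a 1.7-fold lower number from compound 1 to compound 2 (0.24 log units; within the scatter)) puts bromo in place of methyl and stays small, and no measured step shows what the added amino does. No step beyond the scatter is therefore expected in this assay, and the expected step is small (a 1.2-fold higher number from compound 2 to compound 3 (0.09 log units; within the scatter)). Compound 3 is estimated at 20 ug/mL (range 8 ug/mL to 50 ug/mL).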

Compound 3, half-maximal inhibitory concentration: 24.3 ug/mL
Estimate against measurement, compound 3: 1.2-fold (0.08 log units) below; the measured number falls inside the stated range.
By their numbers in this assay, from the lowest: compounds 2, 3 and 1 (each within the scatter of the next).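

In this assay, replacing the substituted benzothiazolyl group on the amine nitrogen with (1,3-benzothiazol-2-yl)amino gives small steps on both sides (a 1.5-fold higher number from compound 2 to compound 3 (0.18 log units; within the scatter); a 1.2-fold lower number from compound 1 to compound 3 (0.06 log units; within the scatter)). This position therefore tolerates the loss of bromo or methyl together with the added amino without any change beyond the scatter. No measurement here explains this result.

The added amino and the lost bromo or methyl come in one change, so neither can be read alone. Going by these compounds, whether a carboxylic acid in their place, or a longer chain, would move the number remains open.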